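Hydrogen in Place of Chloro: Expected Binding Change

This account rests on a few compounds, and the source may have more. Where it says the series, first, only, none or still open, it means among the compounds named here.

Measured compounds:
compound 1, `O=C1c2[nH]nc(NS(=O)(=O)c3ccc4ccccc4c3)c2CCN1CC1CCNCC1`: 94.1%
compound 2, `CC(C)Cc1cc(CNS(=O)(=O)c2cccc(Cl)c2)nn1-c1ccccc1`: 40.8%

Both compounds were tested in an assay on isolated protein for binding affinity to 5-hydroxytryptamine receptor 6 (Homo sapiens), tested at 10 uM; on this read-out lower numbers stand for less inhibition and higher numbers for more inhibition at the one concentration tested (going by the name of the read-out). In this assay compound 1 gives 94.1%, while compound 2 gives 40.8%. Compound 2 therefore stands lowest of the two numbers, and the gap to compound 1 is well beyond the usual scatter of such measurements. The two compounds differ in more than one place, so nothing more than these two values can be read from the pair.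

The unmeasured compound 3, `CC(C)Cc1cc(CNS(=O)(=O)c2ccccc2)nn1-c1ccccc1`, is related to compound 2 by a single change: hydrogen in place of chloro on an aromatic carbon. The chloro that leaves is a single heavy atom with no ring, no donor and no acceptor, so the change is small in size. The expected step from compound 2 to compound 3 in this assay is a number 10.8 percentage points lower from compound 2 to compound 3 (beyond the scatter), a modest fall that may not exceed the scatter. Compound 3 is accordingly estimated at 30%, with a range from 8% to 52%.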

Compound 3, a percentage reported as inhibition, at one concentration (the size of the read-out at that concentration, not a potency): 11.3%
Estimate against measurement, compound 3: 18.7 percentage points above; measured number inside the range.
By their numbers in this assay, from the lowest: compound 3; then compound 2; then compound 1.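

Among these compounds, the replacement of 3-chlorophenyl by phenyl gives the first reading at this position: in this assay it produces a number 29.5 percentage points lower from compound 2 to compound 3 (beyond the scatter), a fall for the loss of one heavy atom. The earlier pair differed in more than one place and could not isolate any single group, whereas here the chloro on the aromatic carbon, meta to a large group, is the only difference, so the change in the number belongs to this one replacement. No measurement in hand bears on the reason for the step, and the compounds give no explanation of it.

Going by these compounds, it remains open whether the higher number of compound 2 is specific to chloro or would also appear with another group on this aromatic carbon, such as a methoxy group, a methyl group or an amine. On these data alone, it is also open whether the same replacement would give a step of similar size on the core of compound 1, where the number lies much higher and the shared features with compound 2 are too few for any transfer to be read.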